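The compounds below may be only part of what the source reports. "The series", "measured", "known", "first", "only" and "open" are said of these compounds alone.

Measured so far:
compound 1, `O=C(Nc1ccnnc1)c1cc(N2CCC(F)CC2)ccc1OCc1ccccc1`: 20000 nM
compound 2, `O=C(Nc1cccnc1)c1cc(C(F)(F)F)ccc1OCc1ccccc1`: < 1000 nM

Among the measured compounds shown here, in a physicochemical assay for solubility, measured as kinetic solubility (on this read-out lower numbers stand for lower solubility and higher numbers for higher solubility), compound 1 gives 20000 nM, the only numeric value in this set. For compound 2 the read-out is a limit rather than a number, < 1000 nM. This is the limit of < 1000 nM in this assay, at which 1 of the 2 values shown sits. For the measured compounds named here, no step between measured compounds differing in one place is available, so the two results stand side by side without a direction being drawn between them.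

Compound 3, `CN1CC2(CCN(c3ccc(OCc4ccccc4)c(C(=O)Nc4ccnnc4)c3)CC2)C1`, differs from compound 1 in one place: a group of 10 heavy atoms (8 carbon, 2 nitrogen; one four-membered non-aromatic ring with 1 hetero atom, one six-membered non-aromatic ring with 1 hetero atom) in place of a group of 7 heavy atoms (5 carbon, 1 nitrogen, 1 fluorine; one six-membered non-aromatic ring with 1 hetero atom), on an aromatic carbon. Going by the values given here, no measured pair here bears on this change, so the expectation for compound 3 rests on the structures alone and carries wide uncertainty. The expected direction in this assay is upward, by a step larger than the usual scatter; the estimated change is a 3.0-fold higher number from compound 1 to compound 3 (0.48 log units; beyond the scatter). Compound 3 is therefore expected to give about 60000 nM in this assay. The plausible range for compound 3 is estimated to run from 20000 nM to 180000 nM.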

Compound 3, solubility: 266000 nM
Estimate against measurement, compound 3: 4.4-fold (0.65 log units) below; the whole stated range lies below it.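

In this assay, the aromatic carbon para to a benzyloxy group and meta to a (pyridazin-4-yl)carbamoyl group now shows itself to be a position where the read-out can move strongly: replacing 4-fluoropiperidin-1-yl with the group carrying one four-membered and one six-membered non-aromatic ring gives a 13-fold higher number from compound 1 to compound 3 (1.12 log units; beyond the scatter). The rest of the core of compound 1 stays unchanged, and both groups are counted with no hydrogen-bond donors and no net charge, so this single exchange is the whole of the structural difference behind the step. No measurement shown explains why the step is this large.

As far as these compounds go, whether the step belongs to the four-membered ring, to the second ring nitrogen with its methyl group or to the larger size of the entering group stays open. From the compounds shown here alone, a morpholine ring, a dimethylamino group or a piperidine without fluorine on the same aromatic carbon would help separate these readings, and it is also open whether the exchange gives a similar step with an amide other than the (pyridazin-4-yl)carbamoyl group.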